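The compounds below may be only part of what the source reports. "The series", "measured", "known", "first", "only" and "open" are said of these compounds alone.

Of the compounds shown here, three built on a shared core have been tested so far in a functional assay on SF-268 cells (Homo sapiens) for antiproliferative activity, read by sulforhodamine B assay, with a stated time of 72 h; on this read-out higher numbers stand for weaker inhibition and lower numbers for stronger inhibition. In this test, compound 1 `S=C(NNc1nncc2ccccc12)Nc1ccccc1` gives 57 nM, compound 2 `O=S(=O)(Nc1ncccn1)c1ccc(Nc2nncc3ccccc23)cc1` gives 34 nM and compound 3 `Clc1ccc(C(/C=C/c2ccccc2)=N\Nc2nncc3ccccc23)cc1` gives 6.3 nM. The numbers for compound 1 and compound 2 lie within the usual scatter of repeated measurements, so the two cannot be told apart. Compound 3 inhibits clearly more strongly than compound 2, by a margin beyond that scatter.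

The next compound to be tested is compound 4 `Cc1cc(NS(=O)(=O)c2ccc(Nc3nncc4ccccc34)cc2)no1`. It carries 5-methyl-1,2-oxazol-3-yl in place of pyrimidin-2-yl on a sulfonamide nitrogen. Among the measured compounds shown here, no measured pair shows this swap, so the data give no direct guide to its effect. Both groups are aromatic rings with hetero atoms, and everything else stays the same, so no change beyond the scatter is expected in this assay. The expected step of a 1.2-fold higher number from compound 2 to compound 4 (0.07 log units; within the scatter) is small, towards slightly weaker inhibition. For compound 4 the estimated value is 40 nM, with an expected range of 13 nM to 120 nM.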

Compound 4, half-maximal inhibitory concentration: 24 nM
Compound 4: middle estimate off by 1.7-fold (0.22 log units), on the high side; the range from low to high includes it.
By their numbers in this assay, from the lowest: compound 3; then compounds 4, 2 and 1 (each within the scatter of the next, the first and the last beyond it).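

In this assay, putting 5-methyl-1,2-oxazol-3-yl in place of pyrimidin-2-yl on a sulfonamide nitrogen gives a 1.4-fold lower number from compound 2 to compound 4 (0.15 log units; within the scatter). Among the compounds shown here, this is the only measured pair at this position, and it gives the earlier compounds' missing direct reading of a change there. A six-membered aromatic ring with 2 hetero atoms can be replaced by a five-membered one with the same count of heavy atoms, and the assay cannot tell the two compounds apart.

Still open is whether this position needs an aromatic ring at all, since neither a bare hydrogen, a methyl group nor an acetyl group on that nitrogen appears among the compounds shown. No measurement is available that would explain why these two groups read alike.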